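Ether side chains on the shared core: oxolane variant

This account rests on a few compounds, and the source may have more. Where it says the series, first, only, none or still open, it means among the compounds named here.

compound 1 `Nc1ccc2cccc(OCC3CCCC3)c2n1` — 53 nM
compound 2 `CC(C)OCCOc1cccc2ccc(N)nc12` — a limit only, > 2000 nM
compound 3 `COC(C)(C)CCOc1cccc2ccc(N)nc12` — 132 nM

In an assay on cells with melanin-concentrating hormone receptor 1 (Homo sapiens) as the target, read by radioligand binding (on this read-out lower numbers stand for stronger inhibition and higher numbers for weaker inhibition), compound 3 gives 132 nM, the higher of the two numbers shown; compound 1 gives 53 nM. For compound 2 the result is a limit, > 2000 nM (the limit of > 2000 nM in this assay, at which 1 of the 3 values shown sits). Bearing on the next step are a 2.5-fold higher number from compound 1 to compound 3 (0.40 log units; beyond the scatter) and, with the limit, an at least 37-fold higher number from compound 1 to compound 2 (1.57 log units; beyond the scatter) together with an at least 15-fold lower number from compound 2 to compound 3 (1.18 log units; beyond the scatter). Compound 4 `Nc1ccc2cccc(OCC3CCCO3)c2n1` carries the change (oxolan-2-yl in place of 2-methoxy-2-methylpropyl on a saturated chain carbon bound to an oxygen on an aromatic ring). The oxolan-2-yl group brings back a ring on that chain carbon, as cyclopentyl in compound 1, while keeping an ether oxygen in the side chain as in compound 3. A modest fall toward compound 1 is therefore expected, a 1.9-fold lower number from compound 3 to compound 4 (0.28 log units; within the scatter). Compound 4 is estimated at 70 nM, within 25 nM to 250 nM.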

Compound 4, half-maximal inhibitory concentration: > 2000 nM
Compound 4 ended at the assay's limit; the forecaster's own chance of this, stated with the estimate: 5%; at least 28-fold (1.45 log units) between middle value and limit.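

Bringing a ring back onto the saturated chain carbon bound to an oxygen on an aromatic ring does not by itself keep the binding result: oxolan-2-yl in place of cyclopentyl gives an at least 37-fold higher number from compound 1 to compound 4 (1.57 log units; beyond the scatter), and oxolan-2-yl in place of 2-methoxy-2-methylpropyl gives an at least 15-fold higher number from compound 3 to compound 4 (1.18 log units; beyond the scatter). An ether oxygen in the side chain is therefore compatible with a measured number in compound 3, but not in compound 4. The step between compound 2 and compound 4 cannot be read, as both are limits: the limit of > 2000 nM in this assay, at which 2 of the 4 values shown sit.

The compounds shown leave open whether the oxygen in the oxolan-2-yl ring accounts for the loss. An oxolan-3-yl or a pyrrolidin-2-yl group on the same carbon would bear on this.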